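Growing the ring on the chain: compound 3 to compound 4

The source may report more compounds than this note shows. Statements on the series, on what has been measured and on what is new or still open speak of the compounds shown alone.

Measured so far:
Compound 1 `O=c1c(S(=O)(=O)c2ccc(F)cc2F)cc2cnc(Nc3ccc4[nH]ccc4c3)nc2n1C1CC1` gives 500 nM in a functional assay on K562 cells (Homo sapiens) for inhibition, read by trypan blue exclusion, with a stated time of 72 h; a lower number here means a stronger inhibitor, a higher number a weaker inhibitor.
Compound 2 `Cn1c(=O)c(S(=O)(=O)Nc2ccc(F)cc2F)cc2cnc(Nc3ccc4[nH]ccc4c3)nc21` gives 5000 nM in this assay.
Compound 3 `O=c1c(S(=O)(=O)c2ccc(F)cc2F)cc2cnc(Nc3ccc4[nH]ccc4c3)nc2n1CC1CC1` gives 1000 nM in this assay.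

Among these three numbers compound 3 stands second highest; its nearest neighbour is compound 1, from which it differs by a 2.0-fold higher number from compound 1 to compound 3 (0.30 log units; within the scatter), while compound 2 lies furthest away. Compound 4 `O=c1c(S(=O)(=O)c2ccc(F)cc2F)cc2cnc(Nc3ccc4[nH]ccc4c3)nc2n1CC1CCCC1` differs from compound 3 by cyclopentyl in place of cyclopropyl on a saturated chain carbon bound to an aromatic nitrogen. Among the compounds with values here, the only measured step that touches this part of the molecule, a 2.0-fold higher number from compound 1 to compound 3 (0.30 log units; within the scatter), stayed within the scatter, so nothing here argues for a large movement in either direction. The number for compound 4 is therefore expected to sit close to that of compound 3, with the step of a 1.2-fold higher number from compound 3 to compound 4 (0.08 log units; within the scatter) estimated to remain within the scatter. The estimate for compound 4 is 1200 nM, with a range from 400 nM to 4000 nM.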

Compound 4, half-maximal inhibitory concentration: 7000 nM
The estimate for compound 4 lay 5.8-fold (0.77 log units) below the measured number, outside the stated range (above it).
By their numbers in this assay, from the lowest: compounds 1 and 3 (each within the scatter of the next); then compounds 2 and 4 (each within the scatter of the next).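

Enlarging the ring on the chain from cyclopropyl to cyclopentyl is not a neutral change at this position: in this assay it gives a 7.0-fold higher number from compound 3 to compound 4 (0.85 log units; beyond the scatter), whereas the one earlier step here, a 2.0-fold higher number from compound 1 to compound 3 (0.30 log units; within the scatter), could not be told from scatter. Replacing cyclopropyl on the aromatic nitrogen with cyclopentylmethyl gives a 14-fold higher number from compound 1 to compound 4 (1.15 log units; beyond the scatter), so the number can move widely with the group at this place. No measurement shown here explains the rise. Going by these compounds, it remains open whether the number climbs steadily with ring size, as cyclobutylmethyl and cyclohexylmethyl would show, or whether an amine on the ring would bring it back down.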